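Nitro in Place of Hydroxy: An Expectation for Compound 4

This account rests on a few compounds, and the source may have more. Where it says the series, first, only, none or still open, it means among the compounds named here.

Compound 1 `O=C(N/N=C/c1ccc(O)cc1)Nc1cccc2ccccc12` was examined in a functional assay on the whole organism (strain Swiss albino) with Mus musculus as the target, in the maximal electroshock model, with a stated time of 0.5 h (a higher number here means that more compound is needed for the effect, a lower number that less compound is needed), where compound 1 gives 100 mg/kg. That number is level with compound 3 `COc1cc(/C=N/NC(=O)Nc2cccc3ccccc23)cc(OC)c1OC`, which in this assay gives 100 mg/kg, so the two share the lowest figure of the three measured compounds within the scatter. The furthest from compound 1 is compound 2 `C/C(=N\NC(=O)Nc1cccc2ccccc12)c1ccccc1`, which in this assay gives 300 mg/kg, a higher number beyond the scatter. Compound 4 `O=C(N/N=C/c1ccc([N+](=O)[O-])cc1)Nc1cccc2ccccc12` has not been measured; it differs from compound 1 by nitro in place of hydroxy on an aromatic carbon. Within the data shown here, no measured pair shows this kind of change, so the step from compound 1 to compound 4 in this assay is expected to be modest, likely none beyond the scatter, as no change at the digits printed from compound 1 to compound 4 (within the scatter). Compound 4 is therefore estimated at 100 mg/kg, within 30 mg/kg to 300 mg/kg.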

Compound 4, minimum effective dose: 300 mg/kg
Beside the measured number, compound 4's estimate is 3.0-fold (0.48 log units) below it, within the range that was stated.
By their numbers in this assay, from the lowest: compounds 1 and 3 (each within the scatter of the next); then compounds 2 and 4 (each within the scatter of the next).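

In this assay, the change of nitro in place of hydroxy, on an aromatic carbon para to a large group, gives a 3.0-fold higher number from compound 1 to compound 4 (0.48 log units; beyond the scatter), the first single-place step read here. It shows that this position is not indifferent to what stands on it, since more compound is needed with nitro there than with hydroxy. Nothing available accounts for this step. Still open, from the compounds shown here alone, is whether an amine or a carboxylic acid at this position would sit with hydroxy or with nitro. Whether hydroxy is itself needed, or nitro alone raises the number, also remains unsettled.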